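The compounds below may be only part of what the source reports. "The series", "measured", "known", "first", "only" and "open" are said of these compounds alone.

Compound 1 `Cc1ccc(S(=O)(=O)N2N=C(c3ccc(N4CCN(C)CC4)cc3)CC2c2ccc(N(C)C)cc2)cc1` gives 10.7% in a functional assay on MDA-MB-231 cells (Homo sapiens) for inhibition, read by sulforhodamine B assay, tested at 10 uM; on this read-out lower numbers stand for less inhibition and higher numbers for more inhibition at the one concentration tested (going by the name of the read-out). Compound 2 `CN1CCN(c2ccc(C3=NN(S(=O)(=O)c4ccc(C#N)cc4)C(c4ccc(N(C)C)cc4)C3)cc2)CC1` gives 99.8%, and the step of a number 89.1 percentage points higher from compound 1 to compound 2 (beyond the scatter) goes with cyano in place of methyl on an aromatic carbon. Compound 3 `Cc1ccc(S(=O)(=O)N2N=C(c3ccc(-n4ccnc4)cc3)CC2c2ccc(N(C)C)cc2)cc1` gives 50.8%; the step of a number 40.1 percentage points higher from compound 1 to compound 3 (beyond the scatter) goes with 1H-imidazol-1-yl in place of 4-methylpiperazin-1-yl on an aromatic carbon, which is also how the core of compound 3 differs from the core of compound 1. Compound 4 `CN(C)c1ccc(C2CC(c3ccc(-n4ccnc4)cc3)=NN2S(=O)(=O)c2ccc(C#N)cc2)cc1` carries cyano in place of methyl on an aromatic carbon relative to compound 3, at a place described in the same words as for compound 2, so this is the same change. For compound 4 a step of a number 44.2 percentage points higher from compound 3 to compound 4 (beyond the scatter) is expected, resting on a number 89.1 percentage points higher from compound 1 to compound 2 (beyond the scatter). Compound 3 already stands at 50.8%, a higher number than compound 1 at 10.7%, so the expected step is held smaller than the earlier one. Compound 4 is estimated at 95%, within 78% to 100%.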

Compound 4, a percentage reported as inhibition, at one concentration (the size of the read-out at that concentration, not a potency): 7.1%
Compound 4: middle estimate off by 87.9 percentage points, on the high side, outside the stated range (below it).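

In this assay, cyano in place of methyl does not carry from one core to another, giving a number 43.7 percentage points lower from compound 3 to compound 4 (beyond the scatter), the opposite direction to the earlier step: the same change on two cores in this assay, a number 89.1 percentage points higher (beyond the scatter) from compound 1 to compound 2 and a number 43.7 percentage points lower (beyond the scatter) from compound 3 to compound 4, 132.8 percentage points apart, beyond the scatter of two such steps. 1H-imidazol-1-yl in place of 4-methylpiperazin-1-yl does not carry either, giving a number 92.7 percentage points lower from compound 2 to compound 4 (beyond the scatter): the same change on two cores in this assay, a number 40.1 percentage points higher (beyond the scatter) from compound 1 to compound 3 and a number 92.7 percentage points lower (beyond the scatter) from compound 2 to compound 4, 132.8 percentage points apart, beyond the scatter of two such steps. The two changes therefore do not add up across these four compounds, but the data do not show why, and readings at one concentration say nothing about potency.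

From the compounds shown here alone, it remains open whether the low number of compound 4 is specific to the pairing of cyano with 1H-imidazol-1-yl. Also open, going by these compounds, is how a morpholine in that place, or a methoxy group in place of cyano, would behave on either core.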